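Swapping 2,4-dichlorophenyl at the limit of the assay

The source may report more compounds than this note shows. Statements on the series, on what has been measured and on what is new or still open speak of the compounds shown alone.

In a functional assay on MCF7 cells (Homo sapiens) for cytotoxicity, read by MTT assay, with a stated time of 72 h (a lower number here means a stronger inhibitor, a higher number a weaker inhibitor), compound 1 `COc1ccccc1/C=C1\CCC/C(=C\c2cccc(OC)c2OC)C1=O` gives 12000 nM. Compound 2 `COc1cccc(/C=C2\CCC/C(=C\c3ccc(O)cc3)C2=O)c1OC` reaches only a limit, > 20000 nM. Compound 3 `COc1cccc(/C=C2\CCC/C(=C\c3ccc(Cl)cc3Cl)C2=O)c1OC` also gives only a limit, > 20000 nM. Compound 4 `COc1cccc(/C=C2\CCC/C(=C\c3ccc(O)c(Cl)c3)C2=O)c1OC` differs from compound 3 on a double-bonded chain carbon bound to a double-bonded ring carbon: 3-chloro-4-hydroxyphenyl in place of 2,4-dichlorophenyl on a double-bonded chain carbon bound to a double-bonded ring carbon. Among the compounds with values here, two measured steps bear on this change: an at least 1.6-fold higher number from compound 1 to compound 2 (0.22 log units; that floor lies within the scatter), and an at least 1.6-fold higher number from compound 1 to compound 3 (0.22 log units; that floor lies within the scatter). The third, a step that the two limits leave unreadable from compound 2 to compound 3, gives no size. On these steps, no change beyond the scatter is expected in this assay, and compound 4 is expected to stay weak. The expected step is an at least 1.1-fold lower number from compound 3 to compound 4 (0.04 log units; that floor lies within the scatter). The estimate for compound 4 is 18000 nM, with an expected range from 7000 nM to 40000 nM.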

Compound 4, half-maximal inhibitory concentration: 16400 nM
Compound 4: the middle estimate sits 1.1-fold (0.04 log units) above what was measured; the range from low to high includes it.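

Compound 4 gives a readable number in this assay at a place where compounds 2 and 3 stop at a limit, not a number: the limit of > 20000 nM in this assay, at which 2 of the 4 values shown sit. The new group therefore separates nothing from the 2,4-dichlorophenyl or from the plain 4-hydroxyphenyl, for both steps (an at least 1.2-fold lower number from compound 3 to compound 4 (0.08 log units; that floor lies within the scatter) and an at least 1.2-fold lower number from compound 2 to compound 4 (0.08 log units; that floor lies within the scatter)) stay within the scatter. The comparison with the 2-methoxyphenyl group also shows no real change (a 1.4-fold higher number from compound 1 to compound 4 (0.14 log units; within the scatter)).

Going by these compounds, whether an amine or a carboxylic acid at this place would bring any step beyond the scatter stays open.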